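The source may hold more compounds than are shown below. What is called first, only, known or untested is meant among the compounds shown, and "the series" means these compounds.

Measured compounds:
Compound 1 `COc1cccc(-c2nc3cc(C)ccc3c(=O)[nH]2)c1`: 100%
Compound 2 `Cc1ccc2nc(-c3cccc(F)c3)[nH]c(=O)c2c1`: 82.9%

In an assay on isolated protein for inhibition of DNA topoisomerase 1 (Homo sapiens), with a stated time of 30 min, tested at 100 uM (a lower number here means a weaker effect, a higher number a stronger effect of the compound at the concentration tested), compound 1 gives 100%, the higher of the two numbers recorded. The nearest neighbour is compound 2, which in this assay gives 82.9%, a number lower than that of compound 1 by a margin beyond the scatter of such measurements. Among the compounds with values here, the two share the same core and differ only in the group on the pendant aromatic ring, but no single-point step between them has been worked out, so their two values are all that can be said of that pair.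

Compound 3 `Cc1cccc(-c2nc3cc(C)ccc3c(=O)[nH]2)c1` is not yet measured. It is derived from compound 1 by one change: methyl in place of methoxy on an aromatic carbon. Within the data shown here, there is no measured step on which this exchange can be gauged. Since compound 1 already gives 100%, the number for compound 3 is expected to stay close, with a step of a number 10 percentage points lower from compound 1 to compound 3 (within the scatter) that is small, directed downward if anywhere, and likely within the scatter. Compound 3 is therefore estimated at 90%, within a range of 72% to 100%.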

Compound 3, a percentage reported as inhibition, at one concentration (the size of the read-out at that concentration, not a potency): 100%
Compound 3: the middle estimate sits 10 percentage points below what was measured; the range from low to high includes it.
By their numbers in this assay, from the lowest: compound 2; then compounds 1 and 3 (each within the scatter of the next).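

In this assay, within the data shown here, the exchange of methoxy for methyl on an aromatic carbon, meta to a large group, gives no change at the digits printed from compound 1 to compound 3 (within the scatter), the first readable step at this place on the pendant ring. The step shows that the read-out at this concentration holds when the group on this carbon loses one heavy atom and its one hydrogen-bond acceptor, so neither the oxygen nor that acceptor is needed to keep the effect seen with compound 1 in this assay. No measurement is available that bears on why the exchange leaves the number as it stands.

The read-out is the size of the effect at a single concentration and not a potency, so the compounds shown leave open whether compound 1 and compound 3 would still match at lower concentrations, where a difference hidden at this one could appear. They also leave open how far this place tolerates other kinds of group, such as an amine, a carboxylic acid or a longer chain like butoxy, in place of the methyl of compound 3.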